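A few compounds are considered here, and "the series" means these few. Any claim that something is new, unique, unknown or untested is made for them only; others in the source may bear on it.

Measured so far in an ADME assay on MCF7 cells (Homo sapiens) for cytotoxicity, read by MTT assay, with a stated time of 48 h; a lower number here means a stronger inhibitor, a higher number a weaker inhibitor:
- compound 1 `Fc1ccc2c(Cn3ccnc3)c(-c3ccc(Cl)cc3)[nH]c2c1`: 45000 nM
- compound 2 `Clc1ccc(-c2[nH]c3cc(Cl)ccc3c2Cn2ccnc2)cc1`: only a limit of the assay, > 1000000 nM
- compound 3 `Fc1ccc(-c2[nH]c3cc(F)ccc3c2Cn2cncn2)cc1`: only a limit of the assay, > 1000000 nM

Within the first pair, the change chloro in place of fluoro on an aromatic carbon made an at least 22-fold higher number from compound 1 to compound 2 (1.34 log units; beyond the scatter). How the core of compound 3 differs from that of compound 1 is not broken down here. Compound 4 `Fc1ccc(-c2[nH]c3cc(Cl)ccc3c2Cn2cncn2)cc1` carries the same change as the first pair, (chloro in place of fluoro on an aromatic carbon), with the place described in identical words. Compound 3 already sits at the limit of > 1000000 nM in this assay, at which 2 of the 3 values shown sit, and the same change made an at least 22-fold higher number from compound 1 to compound 2 (1.34 log units; beyond the scatter) in the first pair, so compound 4 is expected to remain at that limit. The step expected from compound 3 to compound 4 in this assay is a number no higher from compound 3 to compound 4 (the limit leaves the size open). Compound 4 is accordingly estimated at 1000000 nM in this assay, most likely reported as a limit only.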

Compound 4, half-maximal inhibitory concentration: 625000 nM
The estimate for compound 4 lay 1.6-fold (0.20 log units) above the measured number; measured number inside the range.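

In this assay the change of chloro in place of fluoro on an aromatic carbon does not carry over as one fixed step between the two cores: the same change on two cores in this assay, an at least 22-fold higher number (1.34 log units; beyond the scatter) from compound 1 to compound 2 and an at least 1.6-fold lower number (0.20 log units; that floor lies within the scatter) from compound 3 to compound 4, at least 35-fold (1.55 log units) apart, beyond the scatter of two such steps. On the second core the change gives an at least 1.6-fold lower number from compound 3 to compound 4 (0.20 log units; that floor lies within the scatter), and as only that floor is known, no real fall in the number is shown. Both steps rest on a limit of the assay, held by compound 2 and compound 3, so their true sizes stay open, and what sets the two cores apart is not shown.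

On these data alone, only fluoro and chloro appear at this place, so the effect of an amine, a methoxy group or a carboxylic acid there remains open. Few steps can be read in full at this limit: the limit of > 1000000 nM in this assay, at which 2 of the 4 values shown sit.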